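Aryl ether amides: from ethyl toward isopropyl

A few compounds are considered here, and "the series" means these few. Any claim that something is new, unique, unknown or untested is made for them only; others in the source may bear on it.

Values in an assay on HEK293 cells for agonist activity at transient receptor potential cation channel subfamily M member 8 (Homo sapiens), read by fluorescence and calcium flux, with a stated time of 15 min (on this read-out higher numbers stand for an effect only at larger amounts of compound and lower numbers for an effect already at smaller amounts), for the three measured compounds:
compound 1 `CCN(Cc1cccs1)C(=O)COc1ccc(C(F)(F)F)cc1` gives 236 nM
compound 2 `CCc1ccc(OCC(=O)N(CC)Cc2cccs2)cc1` gives 67 nM
compound 3 `CCN(Cc1cccnc1)C(=O)COc1ccc(C)cc1` gives 15400 nM

Compound 2 gives the lowest number of the three in this assay; compound 1 is nearest, and compound 3, which also differs in the heteroaryl part and carries a methyl on the aryl ether ring, lies far away. Within the data shown here, the one step that changes only the group on the aryl ether ring is a 3.5-fold lower number from compound 1 to compound 2 (0.55 log units; beyond the scatter).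

Compound 4 `CCN(Cc1cccs1)C(=O)COc1ccc(C(C)C)cc1` differs from compound 2 by methyl in place of hydrogen on a saturated chain carbon bound to an aromatic carbon and a saturated chain carbon. Among the measured compounds shown here, no measured pair shows this change, so the single step between compound 1 and compound 2 is the only bearing point, and it does not read straight across: it swaps one group for another rather than growing the chain by one carbon. Given that step, compound 4 is estimated to stay close to compound 2, with a step of a 1.1-fold lower number from compound 2 to compound 4 (0.05 log units; within the scatter) in this assay not clearly beyond the scatter in either direction. The estimate for compound 4 in this assay is 60 nM, with a range of 20 nM to 180 nM.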

Compound 4, half-maximal effective concentration: 397 nM
For compound 4 the middle estimate is 6.6-fold (0.82 log units) below the measured one, outside the stated range (above it).
By their numbers in this assay, from the lowest: compound 2; then compounds 1 and 4 (each within the scatter of the next); then compound 3.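

In this assay this position proves sensitive to a single added carbon: methyl in place of hydrogen on the saturated chain carbon, ethyl to isopropyl, gives a 5.9-fold higher number from compound 2 to compound 4 (0.77 log units; beyond the scatter), a change that the earlier step, a swap of one group for another, could not isolate. Isopropyl in place of trifluoromethyl gives a 1.7-fold higher number from compound 1 to compound 4 (0.23 log units; within the scatter), so these two groups are not separated on this read-out, and among the three groups at this position only ethyl stands apart from the others. No measurement shown here accounts for the effect of the added methyl.

Going by these compounds, whether a straight propyl chain or a methoxy group at this position would read with ethyl or with isopropyl stays open. Also open, on these data alone, is whether the ethyl to isopropyl step keeps its size with another group in place of the thiophene-bearing part of the amide.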